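This account rests on a few compounds, and the source may have more. Where it says the series, first, only, none or still open, it means among the compounds named here.

Compound 1, `OC(CCn1nc2c(Br)c(Br)c(Br)c(Br)c2n1)c1cccc(Br)c1`: 1%
Compound 2, `OC(CCn1nc2c(Br)c(Br)c(Br)c(Br)c2n1)c1ccc(F)cc1`: 0%
Compound 3, `COc1cccc(C(O)CCn2nc3c(Br)c(Br)c(Br)c(Br)c3n2)c1`: 16%

These three compounds share one core and differ only in the aromatic ring that sits on the saturated chain carbon bound to an oxygen. They were compared in a functional assay on MCF7 cells (Homo sapiens) for antiproliferative activity, read by MTT assay, with a stated time of 24 h, tested at 100 uM; on this read-out lower numbers stand for a stronger effect and higher numbers for a weaker effect at the one concentration tested. On these numbers compound 3 stands highest, so its effect at the single concentration tested is the weakest of the three: the step of a number 15 percentage points higher from compound 1 to compound 3 (beyond the scatter) and the step of a number 16 percentage points higher from compound 2 to compound 3 (beyond the scatter) both lie beyond the scatter, while a number 1 percentage points lower from compound 1 to compound 2 (within the scatter) lies within it. Compound 4, `OC(CCn1nc2c(Br)c(Br)c(Br)c(Br)c2n1)c1cccc(Cl)c1`, has not yet been measured. It differs from compound 3 in one place: chloro in place of methoxy on an aromatic carbon. The measured step that bears on this change is a number 15 percentage points higher from compound 1 to compound 3 (beyond the scatter), in which a methoxy in place of a bromo raised the number modestly. Compound 4 carries a chloro where compound 1 carries a bromo and compound 3 a methoxy, so the change from compound 3 to compound 4 is expected to move the number back down by a similar amount, beyond the scatter, toward the value of compound 1. Compound 4 is therefore expected to give 3% in this assay, with a range from 0% to 15%. The expected step is a number 13 percentage points lower from compound 3 to compound 4 (beyond the scatter).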

Compound 4, a percentage reported as activity, at one concentration (the size of the read-out at that concentration, not a potency): 0%
Compound 4: the middle estimate sits 3 percentage points above what was measured; the range from low to high includes it.
By their numbers in this assay, from the lowest: compounds 2, 4 and 1 (each within the scatter of the next); then compound 3.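

In this assay, among the compounds shown here, chloro in place of methoxy on the aromatic carbon gives a number 16 percentage points lower from compound 3 to compound 4 (beyond the scatter), while chloro in place of bromo at that same place gives a number 1 percentage points lower from compound 1 to compound 4 (within the scatter); the earlier compounds held only bromo and methoxy here, and now a second halogen shows that bromo and chloro cannot be told apart on this read-out. The 3-chlorophenyl group also sits level with the 4-fluorophenyl group, with no change at the digits printed from compound 2 to compound 4 (within the scatter), so among these four compounds the three carrying a halogen form one group and compound 3, with its methoxy, stands alone at the weaker end, and no compound shown goes against this. Nothing shown here offers a measured explanation for why the methoxy group stands apart.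

Whether this separation holds for other groups on that aromatic carbon stays open, since the compounds shown include no hydroxyl, amine or carboxylic acid there. A single concentration also cannot show whether the three halogen-bearing compounds would separate from one another at lower concentrations.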